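Chloro for methoxy at the assay limit

The compounds below may be only part of what the source reports. "The series", "measured", "known", "first", "only" and "open" are said of these compounds alone.

Compound 1 `CCN(CC)c1ccc(-c2cccc(OC)c2)nn1` reads > 25000 nM as a limit
Compound 2 `COc1ccc(Nc2ccc(-c3ccccc3)nn2)cc1` reads > 25000 nM as a limit

Both readings come from an ADME assay on HaCaT cells (Homo sapiens) for antiproliferative activity, with a stated time of 48 h (on this read-out lower numbers stand for stronger inhibition and higher numbers for weaker inhibition), and neither is an exact number. On these data alone, compound 1 stands at the limit of > 25000 nM in this assay, at which 2 of the 2 values shown sit, and so its true potency stays unknown. Compound 3 `CCN(CC)c1ccc(-c2cccc(Cl)c2)nn1` keeps the core of compound 1 and carries chloro in place of methoxy on an aromatic carbon, meta to a large group (chloro in place of methoxy on an aromatic carbon). Among the measured compounds shown here, no measured pair shows what such a swap does in this assay and the direction cannot be read from these data. The expectation therefore rests on compound 1 and its limit of > 25000 nM and is for no change beyond the scatter. The expected size of the move is a number no higher from compound 1 to compound 3 (the limit leaves the size open) and it may well not be measurable. Compound 3 is estimated at 25000 nM with an expected range from 10000 nM to 50000 nM and may again report only a limit.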

Compound 3, half-maximal inhibitory concentration: > 25000 nM
Compound 3: only a limit was reported; the forecaster's own chance of this, stated with the estimate: 70%; the middle value sits exactly at the limit.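

Among the compounds shown here, compound 1 and compound 3 each report only a limit, so no step between them can be read: the limit of > 25000 nM in this assay, at which 3 of the 3 values shown sit. The compounds shown leave open whether chloro in place of methoxy changes antiproliferative potency at all, since none of them gives an exact number.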